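The compounds below may be only part of what the source reports. "The series", "measured", "known", "first", "only" and "open" are said of these compounds alone.

Measured in a functional assay on a cell-free system (plasma, Oryctolagus cuniculus) for inhibition, with stated times of 5 min, 1 min and 6 min; a lower number here means a stronger inhibitor, a higher number a weaker inhibitor:
- Compound 1 `CCOC(=O)c1c(C)nc(-c2cccc(C#N)c2)n1OC`: 9130 nM
- Compound 2 `CCOC(=O)c1c(C)nc(-c2ccccc2)n1OC`: > 30000 nM (a limit)

For the measured compounds named here, compound 1 is the only compound here with a true number. Compound 2 sits at the limit of > 30000 nM in this assay, at which 1 of the 2 values shown sits.

Compound 3 `CCOC(=O)c1c(C)nc(-c2cccc(C#N)c2)n1C` differs from compound 1 by methyl in place of methoxy on an aromatic nitrogen. Going by the values given here, no measured step touches this place. Among the compounds with values here, the one available step, an at least 3.2-fold higher number from compound 1 to compound 2 (0.51 log units; beyond the scatter), replaces cyano with hydrogen and shows only that a single change can move the number beyond the scatter. No clear direction is therefore expected, and the expected step is small: a 1.1-fold higher number from compound 1 to compound 3 (0.04 log units; within the scatter). For compound 3 the estimated value is 10000 nM, with an expected range of 3000 nM to 30000 nM.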

Compound 3, half-maximal inhibitory concentration: 22100 nM
Compound 3: middle estimate off by 2.2-fold (0.34 log units), on the low side; the measured number falls inside the stated range.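

Methyl in place of methoxy on the aromatic nitrogen is a change that this position registers: in this assay it gives a 2.4-fold higher number from compound 1 to compound 3 (0.38 log units; beyond the scatter), a modest step. The group on this nitrogen, and not only the cyano group, can therefore move the number beyond the scatter, and of the two groups tried here methoxy goes with the lower number. Nothing shown gives a reason for this step.

The compounds shown leave open how a hydroxy group or a longer chain such as ethoxy on this nitrogen would read. They also leave open whether the step holds without the cyano group, since the value of compound 2 is only a limit.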